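Swapping a Chlorine for an Amine on a Short Side Chain

The source may hold more compounds than are shown below. What is called first, only, known or untested is meant among the compounds shown, and "the series" means these compounds.

In a functional assay on MIA PaCa-2 cells (Homo sapiens) for inhibition, read by MTT assay, with a stated time of 72 h (on this read-out higher numbers stand for weaker inhibition and lower numbers for stronger inhibition), compound 1 `Cc1ccc(S(=O)(=O)Nc2cc[nH]c(=O)n2)cc1` reaches only a limit, > 100000 nM. Compound 2 `O=C(CCl)Nc1c[nH]c(=O)[nH]c1=O` gives 17000 nM in this assay, the only number shown. The other value shown, that of compound 1, is a limit (the limit of > 100000 nM in this assay, at which 1 of the 2 values shown sits). Compound 3 `NCC(=O)Nc1c[nH]c(=O)[nH]c1=O` has not yet been measured and differs from compound 2 in one place: amino in place of chloro on a saturated chain carbon bound to a carbonyl carbon. For the measured compounds named here, no step between measured compounds is available, so the expectation rests on this single swap alone. In this assay a weakening step is expected, a 2.9-fold higher number from compound 2 to compound 3 (0.47 log units; beyond the scatter), beyond the usual scatter. Compound 3 is therefore estimated at 50000 nM, within a range of 12000 nM to 200000 nM.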

Compound 3, half-maximal inhibitory concentration: > 100000 nM
Compound 3: a limit, no number (the forecaster's own chance of this, stated with the estimate: 45%); middle value at least 2.0-fold (0.30 log units) away from the limit.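

For the compounds shown here, the swap of chloro for amino gives an at least 5.8-fold higher number from compound 2 to compound 3 (0.76 log units; beyond the scatter) in this assay and so shows that a single atom change on this short side chain can matter, which the earlier compounds could not show. On these data alone, the value of compound 3 is a limit and not a number, so the full size of this step stays unknown. Limits now make up most of the values in this small set: the limit of > 100000 nM in this assay, at which 2 of the 3 values shown sit.

As far as these compounds go, it remains open whether the chlorine itself is needed, or whether a bromine or a hydroxyl group in its place would keep a measurable value. A longer chain carrying the chlorine is equally untested here.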